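A few compounds are considered here, and "the series" means these few. Any claim that something is new, unique, unknown or untested is made for them only; others in the source may bear on it.

Of the compounds shown here, three from one series have been tested in an assay on CHO cells for displacement of a labelled ligand from adenosine receptor A1 (Homo sapiens), read by scintillation counting, tested at 10 uM; on this read-out lower numbers stand for less inhibition and higher numbers for more inhibition at the one concentration tested (going by the name of the read-out). Compound 1, with the structure `Cc1c(-c2ccccc2)sc(N)c1C(=O)c1ccc(Cl)cc1`, gives 1%. Compound 2, with the structure `CC(C)(C)Cc1csc(N)c1C(=O)c1cccc(Cl)c1`, gives 2%. Compound 3, with the structure `CC(C)(C)Cc1c(-c2ccccn2)sc(N)c1C(=O)c1ccc(Cl)cc1`, gives 1%. On the numbers shown, compound 3 stands level with compound 1 at the digits reported, and its gap to compound 2 lies within the usual scatter of repeated measurements, so the three compounds cannot be told apart on this read-out; all three sit near the bottom of the scale.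

Compound 4, with the structure `Cc1ccc(-c2sc(N)c(C(=O)c3ccc(Cl)cc3)c2CC(C)(C)C)cc1`, has not yet been measured in this assay. It differs from compound 3 in one place: 4-methylphenyl in place of pyridin-2-yl on an aromatic carbon. Among the measured compounds shown here, no step between measured compounds is known, so nothing measured speaks for or against this particular change. Given that compound 3 gives 1%, and that compound 1 and compound 2 also sit within the scatter of each other, the step of a number 2 percentage points higher from compound 3 to compound 4 (within the scatter) is expected to be none beyond the scatter. Compound 4 is accordingly estimated to give 3% in this assay, with a range from 0% to 14%.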

Compound 4, a percentage reported as inhibition, at one concentration (the size of the read-out at that concentration, not a potency): 1%
Beside the measured number, compound 4's estimate is 2 percentage points above it; the range from low to high includes it.
By their numbers in this assay, from the lowest: compounds 1, 3, 4 and 2 (each within the scatter of the next).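

In this assay, among the compounds shown here, putting 4-methylphenyl in place of pyridin-2-yl on the aromatic carbon next to the ring sulfur gives no change at the digits printed from compound 3 to compound 4 (within the scatter), and this is the first step that isolates a single change. The ring nitrogen and its hydrogen-bond acceptor leave, a ring of carbon only enters, and the exchange still does not separate the pair, with compound 4 at 1%. For the compounds shown here, nothing available offers an explanation for this result, and at values this low the step shows only that this one exchange at this place brought no measurable gain on this read-out.

The compounds shown leave open whether any group on this aromatic carbon can raise the number in this assay, for instance a carboxylic acid, a basic amine such as piperidine, or a benzyl group with its extra carbon between the two rings. They also leave open whether a longer chain or a free carboxylic acid in place of the neopentyl group would change the picture when the aromatic group stays as it is.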